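The source may hold more compounds than are shown below. What is called first, only, known or untested is meant among the compounds shown, and "the series" means these compounds.

Compound 2 `N#Cc1cc(-c2ccccc2)c2ccc(OCc3cccc(C4(O)CCOCC4)c3)cc2c1` gives 120 nM in an assay on isolated protein with Polyunsaturated fatty acid 5-lipoxygenase (Homo sapiens) as the target (a higher number here means a weaker inhibitor, a lower number a stronger inhibitor), the lowest of the two numbers available, although compound 1 `CC(=O)c1cc(-c2ccccc2)c2ccc(OCc3cccc(C4(O)CCOCC4)c3)cc2c1`, which gives 130 nM in this assay, lies within the scatter of it: the step of a 1.1-fold lower number from compound 1 to compound 2 (0.03 log units; within the scatter) does not separate the two. The change to compound 3 `N#Cc1cc(-c2ccoc2)c2ccc(OCc3cccc(C4(O)CCOCC4)c3)cc2c1` is furan-3-yl in place of phenyl on an aromatic carbon. Among the measured compounds shown here, the only measured step, from acetyl to cyano, concerns a different group on the shared core and so does not bear on this exchange; nothing in the data shows what replacing the phenyl ring does in this assay. For the measured compounds named here, with no step to lean on, the exchange is expected to leave the number roughly where compound 2 stands, and the expected step is a 1.3-fold higher number from compound 2 to compound 3 (0.10 log units; within the scatter), none beyond the scatter. Compound 3 is therefore estimated at 150 nM in this assay, with a range from 50 nM to 450 nM.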

Compound 3, half-maximal inhibitory concentration: 30 nM
The estimate for compound 3 lay 5.0-fold (0.70 log units) above the measured number, outside the stated range (below it).
By their numbers in this assay, from the lowest: compound 3; then compounds 2 and 1 (each within the scatter of the next).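

On this aromatic carbon, ortho to a fused ring, the choice of ring matters in this assay: furan-3-yl in place of phenyl gives a 4.0-fold lower number from compound 2 to compound 3 (0.60 log units; beyond the scatter) and lies beyond the scatter. The earlier exchange of acetyl for cyano, at a different place on the shared core, had not separated compound 1 and compound 2, so this is the first single change shown that moves the number, with the five-membered ring holding one oxygen giving the lower value. The data at hand offer no explanation for this gain.

The compounds shown leave open whether the oxygen or the smaller ring accounts for the step, which a thiophen-3-yl or cyclopentyl group at this position would help to separate. They also leave open whether furan-2-yl or pyridin-3-yl would serve as well as furan-3-yl here.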